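The source may hold more compounds than are shown below. What is called first, only, known or untested is meant among the compounds shown, and "the series" means these compounds.

Compound 1 `Nc1oncc1-c1ccccc1` is the starting point. In an assay on SW48 cells for inhibition of Tryptophan 2,3-dioxygenase (Homo sapiens), read by fluorescence, with a stated time of 30 min (on this read-out higher numbers stand for an effect only at larger amounts of compound and lower numbers for an effect already at smaller amounts), compound 1 gives 85 nM. Compound 2 `Cc1noc(N)c1-c1ccccc1` carries the change (methyl in place of hydrogen on an aromatic carbon), and in this assay compound 2 gives 9700 nM; the step of a 110-fold higher number from compound 1 to compound 2 (2.06 log units; beyond the scatter) is large. Compound 3 `Nc1oncc1-n1cccn1` has a different core; the difference between the two cores is not broken down here. In this assay compound 3 gives 230 nM. Compound 4 `Cc1cnn(-c2cnoc2N)c1` differs from compound 3 by methyl in place of hydrogen on an aromatic carbon. This is the same kind of change as the earlier one, not the same: there the methyl entered on a five-membered aromatic ring with 1 nitrogen and 1 oxygen, two ring bonds from the ring atom that bears an amino group, whereas here it enters on a five-membered aromatic ring with 2 nitrogen, two ring bonds from the ring nitrogen. A smaller step is expected here, roughly a 2.2-fold higher number from compound 3 to compound 4 (0.34 log units; beyond the scatter), because a 110-fold higher number from compound 1 to compound 2 (2.06 log units; beyond the scatter) was made on the ring that bears the amino group, while in compound 4 the methyl enters the other ring. Compound 4 is therefore estimated at 500 nM, expected between 150 nM and 1800 nM.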

Compound 4, half-maximal effective concentration: 340 nM
For compound 4 the middle estimate is 1.5-fold (0.17 log units) above the measured one; the measured number falls inside the stated range.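

In this assay the methyl gives a 1.5-fold higher number from compound 3 to compound 4 (0.17 log units; within the scatter), so on this core the two numbers cannot be told apart. The same change therefore does not carry over in size from one core to the other in this series: the same change on two cores in this assay, a 110-fold higher number (2.06 log units; beyond the scatter) from compound 1 to compound 2 and a 1.5-fold higher number (0.17 log units; within the scatter) from compound 3 to compound 4, 77-fold (1.89 log units) apart, beyond the scatter of two such steps

Going by these compounds alone, this rests on only two pairs, with the methyl on a different kind of ring in each, so it shows that the step on one core does not predict the step on the other, but not why, nor how the change would behave on a further core. The compounds shown leave open how a longer chain such as ethyl, an amine or a carboxylic acid would read in place of this methyl on either core.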